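From 2-ethylphenyl to octyl on a shared core

This account rests on a few compounds, and the source may have more. Where it says the series, first, only, none or still open, it means among the compounds named here.

Three compounds share one core and differ only in the group on an aromatic nitrogen. In a functional assay on HepG2 cells (Homo sapiens) for antiproliferative activity, read by MTT assay (a lower number here means a stronger inhibitor, a higher number a weaker inhibitor), compound 1 `Cc1c(-n2cc(COc3ccc(/C=C/C(=O)c4ccc5c(c4O)CCC(C)(C)O5)cc3)nn2)cccc1[N+](=O)[O-]` gives 115000 nM, compound 2 `COc1ccc(-n2cc(COc3ccc(/C=C/C(=O)c4ccc5c(c4O)CCC(C)(C)O5)cc3)nn2)c([N+](=O)[O-])c1` gives 120000 nM and compound 3 `CCc1ccccc1-n1cc(COc2ccc(/C=C/C(=O)c3ccc4c(c3O)CCC(C)(C)O4)cc2)nn1` gives 67800 nM. Compound 3 therefore cannot be separated from the other two, as the steps to it are a 1.7-fold lower number from compound 1 to compound 3 (0.23 log units; within the scatter) and a 1.8-fold lower number from compound 2 to compound 3 (0.25 log units; within the scatter). The remaining step is a 1.0-fold higher number from compound 1 to compound 2 (0.02 log units; within the scatter).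

Compound 4 `CCCCCCCCn1cc(COc2ccc(/C=C/C(=O)c3ccc4c(c3O)CCC(C)(C)O4)cc2)nn1` carries octyl in place of 2-ethylphenyl on an aromatic nitrogen. All three measured steps exchange one substituted phenyl group for another and all stay small, but none shows what happens when the ring is lost. The data hold no direct guide to this change, so the range must stay wide. In this assay, the expected change is no larger than the scatter, with an estimated 1.1-fold higher number from compound 3 to compound 4 (0.04 log units; within the scatter). For compound 4, the estimated value is 75000 nM, with an expected range of 30000 nM to 180000 nM.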

Compound 4, half-maximal inhibitory concentration: 74100 nM
The estimate for compound 4 lay 1.0-fold (0.01 log units) above the measured number; the measured number falls inside the stated range.
By their numbers in this assay, from the lowest: compounds 3, 4, 1 and 2 (each within the scatter of the next).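

Putting octyl, which has no ring, in place of 2-ethylphenyl, with the same count of heavy atoms, leaves the result in this assay within the scatter, with a 1.1-fold higher number from compound 3 to compound 4 (0.04 log units; within the scatter). The steps from the other two groups, 4-methoxy-2-nitrophenyl and 2-methyl-3-nitrophenyl, also stay within the scatter, with a 1.6-fold lower number from compound 2 to compound 4 (0.21 log units; within the scatter) and a 1.6-fold lower number from compound 1 to compound 4 (0.19 log units; within the scatter), so among these four compounds, an aromatic ring on this nitrogen does not separate one number from another. Nothing available explains why this exchange leaves the number within the scatter.

All four compounds lie within the scatter of the next, so they do not show whether any group at this position can move the number further. On these data alone, whether a shorter chain such as butyl, or a chain ending in an amine or a carboxylic acid, would fall outside this narrow band remains open.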